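Series at the limit: from compound 3 to compound 4

The compounds below may be only part of what the source reports. "The series", "measured", "known", "first", "only" and "open" are said of these compounds alone.

Measured in an ADME assay on HEK293 cells (Homo sapiens) for cytotoxicity, read by MTT assay, with a stated time of 72 h; a lower number here means a stronger inhibitor, a higher number a weaker inhibitor:
compound 1 `COc1ccc(C2=C(c3cc(OC)c(OC)c(OC)c3)C(=O)CC2O[SiH2]C(C)(C)C)cc1OC` gives > 100 ug/mL
compound 2 `COc1cc(C2=C(c3ccc(SC)cc3)CC(O[SiH2]C(C)(C)C)C2=O)cc(OC)c1OC` gives > 100 ug/mL
compound 3 `COc1cc(C2=C(c3ccccc3)C(O[SiH2]C(C)(C)C)CC2=O)cc(OC)c1OC` gives > 100 ug/mL

Each of these entries is a limit of the assay and not a number. Compound 3 therefore has no numerical position in the series, and it shares its place with the other two, as the record shows: the limit of > 100 ug/mL in this assay, at which 3 of the 3 values shown sit.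

Compound 4 `COc1ccc(C2=C(c3cc(OC)c(OC)c(OC)c3)C(=O)CC2O[SiH2]C(C)(C)C)cc1O` is the next compound to be read. The change from compound 3 is 3-hydroxy-4-methoxyphenyl in place of phenyl on a double-bonded ring carbon, with 3-hydroxy-4-methoxyphenyl in place of phenyl on a double-bonded ring carbon.

Among the measured compounds shown here, one measured step touches this ring carbon: a step that the two limits leave unreadable from compound 1 to compound 3. It offers no size to carry over and no direction. For the measured compounds named here, all that the series shows in this assay is that no compound has yet given a number. On that basis, no step beyond the scatter is expected, and compound 4 will most likely be reported as a limit again. The data do not exclude a number under the limit, so the expected range is open mainly on the lower side. The expected step is a number no higher from compound 3 to compound 4 (the limit leaves the size open). For compound 4 the estimated value is 100 ug/mL, with an expected range from 25 ug/mL to 200 ug/mL.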

Compound 4, half-maximal inhibitory concentration: 42 ug/mL
Compound 4: middle estimate off by 2.4-fold (0.38 log units), on the high side, within the range that was stated.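

In this assay, hydrogen in place of methyl on an oxygen on an aromatic ring is the only difference behind an at least 2.3-fold lower number from compound 1 to compound 4 (0.37 log units; beyond the scatter), so this single change on the 3,4-dimethoxyphenyl group is enough to bring the series off its limit. At the same double-bonded ring carbon, 3-hydroxy-4-methoxyphenyl in place of phenyl gives an at least 2.3-fold lower number from compound 3 to compound 4 (0.37 log units; beyond the scatter), whereas the earlier step at this carbon cannot be read, as both of its ends are limits. Compound 4 is therefore the only entry with a number, and the other compounds remain limits of the assay: the limit of > 100 ug/mL in this assay, at which 3 of the 4 values shown sit.

On these data alone, both readable steps start from a limit, so their full size remains open, and one hydroxyl-bearing compound gives no indication of how far the effect extends across the series. Also open, as far as these compounds go, is whether an amine or a carboxylic acid in place of the hydroxyl on the same aromatic ring would give a number under the limit, and whether the same hydrogen-for-methyl change would give a step in the core of compound 2 or compound 3.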